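The source may hold more compounds than are shown below. What is called first, only, known or untested is meant among the compounds shown, and "the series" means these compounds.

Measured so far in an ADME assay on L02 cells (Homo sapiens) for cytotoxicity, read by MTT assay, with a stated time of 72 h (a higher number here means a weaker inhibitor, a lower number a stronger inhibitor), on this series
- compound 1 (`O=C(O)CCC(=O)OCCOc1no[n+]([O-])c1S(=O)(=O)c1ccccc1`) gives 36000 nM
- compound 2 (`O=C(O)CCCC(=O)OCCCOc1no[n+]([O-])c1S(=O)(=O)c1ccccc1`) gives 35000 nM

Compound 1 has only compound 2 as a neighbour on these numbers, and the two values lie within the scatter of each other. Going by the values given here, no pair of measured compounds differs in one place only, so the data hold no direct measure of what a single change does in this assay here.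

The next compound is compound 3 (`O=C(O)c1ccccc1C(=O)OCCOc1no[n+]([O-])c1S(=O)(=O)c1ccccc1`). Against compound 1 it carries 2-carboxyphenyl in place of 2-carboxyethyl on a carbonyl carbon. Among the compounds with values here, no measured compound carries 2-carboxyphenyl, so any expectation is loose.

Within the data shown here, with compound 1 at 36000 nM and compound 2 at 35000 nM as the only reference values, no step beyond the scatter is expected, and no firm direction. The expected step is small (a 1.2-fold lower number from compound 1 to compound 3 (0.08 log units; within the scatter)) and remains an estimate. For compound 3 the estimated value is 30000 nM with an expected range from 12000 nM to 70000 nM in this read-out.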

Compound 3, half-maximal inhibitory concentration: 37000 nM
The estimate for compound 3 lay 1.2-fold (0.09 log units) below the measured number; low and high end bracket the measured number.
By their numbers in this assay, from the lowest: compounds 2, 1 and 3 (each within the scatter of the next).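

In this assay, going by these compounds alone, the change to 2-carboxyphenyl in place of 2-carboxyethyl on a carbonyl carbon gives a 1.0-fold higher number from compound 1 to compound 3 (0.01 log units; within the scatter) and is the first single-place comparison available. At this position the read-out therefore stays within the scatter when the group grows from 5 to 9 heavy atoms and gains one six-membered aromatic ring of carbon only, while the hydrogen-bond donor and acceptor counts are the same on both sides. No measurement at hand offers an explanation for this result.

As far as these compounds go, it remains open whether this position would read the same in this assay with a group that lacks the carboxylic acid, such as a simple alkyl chain or an amine. Also open, from the compounds shown here alone, is whether a methoxy group on the ring of 2-carboxyphenyl, or a change in the shared core rather than at this position, would move the number beyond the scatter.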